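Carbamate alkyl change on a thiazolidinedione series

The source may report more compounds than this note shows. Statements on the series, on what has been measured and on what is new or still open speak of the compounds shown alone.

Measured compounds in a functional assay on CHO-K1 cells for agonist activity at Glucose-dependent insulinotropic receptor (Homo sapiens), read by cAMP accumulation and immunoassay, with a stated time of 1 h; on this read-out higher numbers stand for an effect only at larger amounts of compound and lower numbers for an effect already at smaller amounts:
- compound 1 `CCOC(=O)N1CCC(Oc2ncnc(Oc3ccc(/C=C4\SC(=O)NC4=O)cc3)c2C)CC1` gives 157 nM
- compound 2 `CCOC(=O)N1CCC(Oc2cc(Oc3ccc(/C=C4\SC(=O)NC4=O)cc3)ncn2)CC1` gives 790 nM
- compound 3 `COC(=O)N1CCC(Oc2cc(Oc3cccc(/C=C4\SC(=O)NC4=O)c3)ncn2)CC1` gives 1870 nM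

Compound 3 stands at the highest number of the three. Among the measured compounds shown here, the only single-place step measured so far is a 5.0-fold higher number from compound 1 to compound 2 (0.70 log units; beyond the scatter), which concerns the aromatic methyl and not the carbamate. Compound 3 differs from compound 2 in the ring position of the thiazolidinedione-bearing linkage and in the carbamate alkyl at the same time, so its gap to compound 2 cannot be assigned to either change alone.

Compound 4 `CC(C)(C)OC(=O)N1CCC(Oc2cc(Oc3cccc(/C=C4\SC(=O)NC4=O)c3)ncn2)CC1` is compound 3 with tert-butyl in place of methyl on an oxygen next to a carbonyl group. No measured step bears on this change, so the expectation rests only on the absence of any shown effect of the carbamate alkyl. The step is therefore expected to be a 1.4-fold lower number from compound 3 to compound 4 (0.16 log units; within the scatter), with no direction beyond the scatter. The estimate for compound 4 in this assay is 1300 nM, in the range 400 nM to 4500 nM.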

Compound 4, half-maximal effective concentration: 125 nM
For compound 4 the middle estimate is 10-fold (1.02 log units) above the measured one, outside the stated range (below it).
By their numbers in this assay, from the lowest: compounds 4 and 1 (each within the scatter of the next); then compound 2; then compound 3.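

In this assay, the carbamate alkyl turns out to be a position that matters: a 15-fold lower number from compound 3 to compound 4 (1.17 log units; beyond the scatter), so tert-butyl in place of methyl on an oxygen next to a carbonyl group is a large change and not a silent one on this core. Among the compounds shown here, this is the only single-place step at the carbamate, as the earlier step, a 5.0-fold higher number from compound 1 to compound 2 (0.70 log units; beyond the scatter), concerned the aromatic methyl. Nothing measured here gives a reason for the new step.

Still open, going by these compounds, is whether the same exchange carries over to the core of compound 2, which bears an ethyl carbamate. Also open, on these data alone, is how isopropyl or a longer chain such as n-butyl would read at this position, since only methyl and tert-butyl are compared directly.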